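The compounds below may be only part of what the source reports. "The series", "measured", "known", "first", "only" and "open" are said of these compounds alone.

Measured so far in this series:
compound 1 `CCCCCCCCCCC#Cc1cc2cn([C@@H]3O[C@H](CO)[C@@H](O)[C@@H]3O)c(=O)nc2o1`: 116000 nM
compound 2 `CCCCCCCCCCC#Cc1cc2cn([C@H]3C[C@H](O)[C@@H](CO)O3)c(=O)nc2o1`: 36000 nM
compound 3 `CCCCCCC#Cc1cc2cn([C@H]3C[C@H](O)[C@@H](CO)O3)c(=O)nc2o1`: 138000 nM

All three numbers come from a functional assay on HEL cells (Homo sapiens) for cytotoxicity; a lower number here means that less compound is tolerated, a higher number that more compound is tolerated. Compound 4 `CCCCCCC#Cc1cc2cn([C@@H]3O[C@H](CO)[C@@H](O)[C@@H]3O)c(=O)nc2o1` has not yet been run there. Compound 4 differs from compound 3 by hydroxy in place of hydrogen on a saturated ring carbon. The same change already stands between two measured compounds: compound 1 differs from compound 2 by hydroxy in place of hydrogen on a saturated ring carbon, and that step gave a 3.2-fold higher number from compound 2 to compound 1 (0.51 log units; beyond the scatter). The two cores differ by hydrogen in place of butyl on a saturated chain carbon, six bonds along the chain from a triple-bonded carbon, a change that on its own gave a 3.8-fold higher number from compound 2 to compound 3 (0.58 log units; beyond the scatter). Around the entering hydroxy the surroundings read the same word for word in both pairs, so the change is the same one, carried over onto the shorter chain. Among the measured compounds compound 3 has the highest number, with compound 1 within the scatter of it and compound 2 beyond.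

Going by the values given here, for compound 4 a step of a 2.5-fold higher number from compound 3 to compound 4 (0.40 log units; beyond the scatter) is expected, resting on the single earlier step of a 3.2-fold higher number from compound 2 to compound 1 (0.51 log units; beyond the scatter) and tempered by the fact that only one precedent exists. The estimated value for compound 4 is 350000 nM, expected to fall between 150000 nM and 900000 nM.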

Compound 4, half-maximal cytotoxic concentration: > 53000 nM
Compound 4 was reported as a limit (the forecaster's own chance of this, stated with the estimate: 25%); the middle value lies beyond the limit too.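

Compound 4 is reported only as a limit: the limit of > 53000 nM in this assay, at which 1 of the 4 values shown sits. Neither the step from compound 3 to compound 4 nor the step from compound 1 to compound 4 can be read from it. The compounds shown leave open how large a step hydroxy in place of hydrogen on a saturated ring carbon gives on the core of compound 3.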